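A few compounds are considered here, and "the series" means these few. Any claim that something is new, unique, unknown or untested is made for them only; others in the source may bear on it.

Series notes.

Measured so far:
compound 1 `C=CC(=O)Nc1cccc(NC(=O)CSc2nc(Nc3ccccc3Br)c3ccccc3n2)c1`, 19300 nM in a functional assay on NCI-H1975 cells (Homo sapiens) for inhibition, read by MTT assay, with a stated time of 72 h; a lower number here means a stronger inhibitor, a higher number a weaker inhibitor;
compound 2 `C=CC(=O)Nc1cccc(NC(=O)CSc2nc(Nc3cccc(OC)c3)c3ccccc3n2)c1`, 7940 nM.

Among the compounds with values here, compound 2 gives the lower of the two numbers; the only step measured is a 2.4-fold lower number from compound 1 to compound 2 (0.39 log units; beyond the scatter), an aryl-for-aryl swap on the same nitrogen. Compound 3 `C=CC(=O)Nc1cccc(NC(=O)CSc2nc(Nc3ccc(C(F)(F)F)cc3)c3ccccc3n2)c1` is not yet measured. It differs from compound 2 in this way: 4-(trifluoromethyl)phenyl in place of 3-methoxyphenyl on a nitrogen on an aromatic ring. Within the data shown here, no measured step reports a trifluoromethyl group at this place, so the step from compound 1 to compound 2 is the only guide to how much an aryl swap here can move the number, and it gives no direction for this one. The expected step is therefore small, a 1.3-fold higher number from compound 2 to compound 3 (0.10 log units; within the scatter), within the scatter. Compound 3 is estimated at 10000 nM, range 3000 nM to 32000 nM.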

Compound 3, half-maximal inhibitory concentration: 12900 nM
The estimate for compound 3 lay 1.3-fold (0.11 log units) below the measured number, and the stated range covers the measured number.
By their numbers in this assay, from the lowest: compounds 2, 3 and 1 (each within the scatter of the next, the first and the last beyond it).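

The 4-(trifluoromethyl)phenyl on this nitrogen gives a 1.6-fold higher number from compound 2 to compound 3 (0.21 log units; within the scatter) and a 1.5-fold lower number from compound 1 to compound 3 (0.17 log units; within the scatter) in this assay and so separates from neither earlier aryl group. Of the three aryl groups now compared at this position, only 2-bromophenyl and 3-methoxyphenyl stand beyond the scatter of each other. No available evidence accounts for these differences. 

From the compounds shown here alone, all three groups on this nitrogen are substituted phenyl rings, so the effect of a piperazine, a carboxylic acid or a longer chain carried on that ring remains open. The shown compounds also leave open whether any change elsewhere on the shared core moves the number further.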